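This account rests on a few compounds, and the source may have more. Where it says the series, first, only, none or still open, it means among the compounds named here.

Of the compounds shown here, two have been measured so far in a functional assay on HCT-15 cells (Homo sapiens) for cytotoxicity, read by sulforhodamine B assay, with a stated time of 72 h (on this read-out lower numbers stand for stronger inhibition of growth and higher numbers for weaker inhibition of growth), and they lie well apart. Compound 1 (`O=C(Nc1cc(C(F)(F)F)cc(C(F)(F)F)c1)C1CCc2ccccc2N1C(=O)c1ccccc1Cl`) gives 4050 nM as the lower of the two numbers, and compound 2 (`COc1ccc(NC(=O)C2CCc3ccccc3N2)cc1`) gives 50200 nM on the far side of the usual scatter of repeated measurements. The next compound to follow is compound 3 (`O=C(Nc1cc(C(F)(F)F)cc(C(F)(F)F)c1)C1CCc2ccccc2N1C(=O)c1cccc(Cl)c1`). In it the core of compound 1 stays and one group changes, with 3-chlorophenyl in place of 2-chlorophenyl on a carbonyl carbon. Compound 1 and compound 3 hold the same atoms joined differently, so this is a very small structural change. Among the compounds with values here, no pair of measured compounds shows what a change of this kind does, and the data offer no argument for either direction. The natural starting point is therefore compound 1 at 4050 nM as the reference value. A step no larger than the scatter is expected in this assay, and a 1.0-fold lower number from compound 1 to compound 3 (0.01 log units; within the scatter) is the estimated size of it. Compound 3 is estimated at 4000 nM with 1700 nM to 10000 nM as the expected range.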

Compound 3, concentration for 50% growth inhibition: 625 nM
Estimate against measurement, compound 3: 6.4-fold (0.81 log units) above; the measured number lies below the stated range.
By their numbers in this assay, from the lowest: compound 3; then compound 1; then compound 2.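

In this assay, 3-chlorophenyl in place of 2-chlorophenyl on a carbonyl carbon gives a 6.5-fold lower number from compound 1 to compound 3 (0.81 log units; beyond the scatter), so the read-out at this place depends on how the same atoms are joined, and not only on which atoms are present. The two groups match in everything counted here, with the same heavy atoms, one six-membered aromatic ring of carbon only and no net charge, so those counts alone do not separate this pair. Nothing among the data explains why the two groups give different numbers.

The compounds shown compare only these two chlorophenyl groups at this place, so it remains open how a plain phenyl, a bromophenyl or a non-aromatic group such as an amine or a longer chain would read there. Compound 2 differs from compound 1 and compound 3 in more than one place, so it cannot show whether the same step would hold on a different amide group elsewhere in the molecule.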